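A few compounds are considered here, and "the series" means these few. Any claim that something is new, unique, unknown or untested is made for them only; others in the source may bear on it.

Of the compounds shown here, three sharing one core have been measured in a functional assay on the whole organism (strain Swiss albino) for inhibition, with Mus musculus as the target, with stated times of 30 min, 10 min and 20 min; a lower number here means that less compound is needed, a higher number that more compound is needed for the effect. Compound 1, `O=C(CN1CCN(c2ccccc2)CC1)N(c1ccccc1)c1ccccc1`, gives 27 mg/kg in this assay. Compound 2, `Cc1ccc(N2CCN(CC(=O)N(c3ccccc3)c3ccccc3)CC2)cc1`, carries a methyl in place of hydrogen on an aromatic carbon, and in this assay compound 2 gives 31.2 mg/kg; the step of a 1.2-fold higher number from compound 1 to compound 2 (0.06 log units; within the scatter) stays within the scatter. Compound 3, `O=C(CN1CCN(c2ccc(Cl)c(Cl)c2)CC1)N(c1ccccc1)c1ccccc1`, carries a 3,4-dichlorophenyl in place of phenyl on the amine nitrogen in the ring. For compound 3 this assay reports only a limit, > 20 mg/kg, and not a number. Because of the limit of > 20 mg/kg in this assay, at which 1 of the 3 values shown sits, the steps a step that the limit leaves unreadable from compound 1 to compound 3 and a step that the limit leaves unreadable from compound 2 to compound 3 cannot be read in size. Compound 4, `O=C(CN1CCN(c2ccc([N+](=O)[O-])cc2)CC1)N(c1ccccc1)c1ccccc1`, is not yet measured; it differs from compound 3 by 4-nitrophenyl in place of 3,4-dichlorophenyl on an amine nitrogen in a ring. Going by the values given here, no measured step matches this change, and the only readable step, a 1.2-fold higher number from compound 1 to compound 2 (0.06 log units; within the scatter), shows no movement beyond the scatter. Compound 4 is therefore estimated at 30 mg/kg, within a range from 15 mg/kg to 60 mg/kg. This estimate means an expected step that the limit leaves unreadable from compound 3 to compound 4, though a limit for compound 4 remains possible.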

Compound 4, dose for half-maximal effect: > 40 mg/kg
Compound 4: no number, only a limit; the forecaster's own chance of this, stated with the estimate: 35%; middle value at least 1.3-fold (0.12 log units) from the limit.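

In this assay compound 4 gives only a limit (> 40 mg/kg) and not a number. Its 4-nitrophenyl group yields an at least 1.4-fold higher number from compound 1 to compound 4 (0.17 log units; that floor lies within the scatter) and an at least 1.2-fold higher number from compound 2 to compound 4 (0.10 log units; that floor lies within the scatter) but both are only floors that lie within the scatter, so the direction is suggested while a real rise in the dose needed is not shown. The steps involving compound 3 cannot be read in size, so 4-nitrophenyl and 3,4-dichlorophenyl cannot be ranked against each other.

Still open, on these data alone, is how large the true dose of compound 4 is, and whether any group on this aromatic ring can lower the number at all. A 4-aminophenyl or 4-carboxyphenyl group on the same amine nitrogen in the ring would test that question with a different kind of group.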